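A few compounds are considered here, and "the series" means these few. Any claim that something is new, unique, unknown or untested is made for them only; others in the source may bear on it.

Compound 1 (`Cc1ccc(/C(COc2ccc(Br)cc2)=N\NC(N)=S)cc1`) gives 13200 nM
Compound 2 (`COc1ccc(OC/C(=N\NC(N)=S)c2ccc(Br)cc2)cc1`) gives 102000 nM

In an ADME assay on L929 cells (Mus musculus) for cytotoxicity, read by resazurin assay, with a stated time of 96 h (a higher number here means that more compound is tolerated, a lower number that less compound is tolerated), compound 2 stands highest of the two measured compounds, beyond the scatter from compound 1. Compound 3 (`NC(=S)N/N=C(\COc1ccc(I)cc1)c1ccc(Br)cc1`) has iodo in place of methoxy on an aromatic carbon, para to a large group (iodo in place of methoxy on an aromatic carbon). Going by the values given here, no measured step isolates this change, so the expectation rests only on the two values at hand. A lower number in this assay is expected, by more than the scatter, moving towards compound 1 at 13200 nM without quite reaching it. The estimate means a 4.6-fold lower number from compound 2 to compound 3 (0.67 log units; beyond the scatter) as the expected step. Compound 3 is expected to read 22000 nM with an estimated range from 6000 nM to 70000 nM in this measurement.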

Compound 3, half-maximal cytotoxic concentration: < 20400 nM
Compound 3: no number, only a limit; the forecaster's own chance of this, stated with the estimate: 5%; middle value at least 1.0-fold (0.03 log units) from the limit.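

In this assay, iodo in place of methoxy on an aromatic carbon, para to a large group, gives an at least 5.0-fold lower number from compound 2 to compound 3 (0.69 log units; beyond the scatter). Going by these compounds alone, this is the first change confined to one place, and it shows that the group held at this position alters how much compound the cells tolerate. The reading for compound 3 is a limit, not a number, so only the least size of the step is known: the limit of < 20400 nM in this assay, at which 1 of the 3 values shown sits.

From the compounds shown here alone, how far compound 3 lies beyond its limit stays open. So does where an amine, a carboxylic acid or a longer chain at this position would fall relative to compound 2.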